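The source may report more compounds than this note shows. Statements on the series, on what has been measured and on what is new or still open speak of the compounds shown alone.

Measured compounds:
Compound 1 `C[C@@H](O[C@H]1CN2C(=O)C=C(c3ccc(CO)cc3)CC2[C@@H]1c1ccc(F)cc1)c1cc(C(F)(F)F)cc(C(F)(F)F)c1` gives 0.39 nM in an assay on CHO cells for displacement of a labelled ligand from Substance-P receptor (Homo sapiens); on this read-out higher numbers stand for weaker inhibition and lower numbers for stronger inhibition.
Compound 2 `Cc1cc(C2=CC(=O)N3C[C@H](O[C@H](C)c4cc(C(F)(F)F)cc(C(F)(F)F)c4)[C@@H](c4ccc(F)cc4)C3C2)ccn1` gives 0.51 nM in this assay.
Compound 3 `COc1cc(C2=CC(=O)N3C[C@H](O[C@H](C)c4cc(C(F)(F)F)cc(C(F)(F)F)c4)[C@@H](c4ccc(F)cc4)C3C2)ccn1` gives 1.1 nM in this assay.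

Among these three, compound 1 holds the lowest number. Compound 2 sits nearest to it, with a 1.3-fold higher number from compound 1 to compound 2 (0.12 log units; within the scatter), a gap that lies within the scatter. Compound 3 sits furthest, with a 2.8-fold higher number from compound 1 to compound 3 (0.45 log units; beyond the scatter). The two aromatic rings that enter in compounds 2 and 3 differ from one another only in one group, and that change gives a 2.2-fold higher number from compound 2 to compound 3 (0.33 log units; beyond the scatter).

Compound 4 `C[C@@H](O[C@H]1CN2C(=O)C=C(c3ccc[n+]([O-])c3)CC2[C@@H]1c1ccc(F)cc1)c1cc(C(F)(F)F)cc(C(F)(F)F)c1` is not yet measured. Compared with compound 1 the change is a group of 7 heavy atoms (5 carbon, 1 nitrogen, 1 oxygen; one six-membered aromatic ring with 1 hetero atom) in place of a group of 8 heavy atoms (7 carbon, 1 oxygen; one six-membered aromatic ring of carbon only), on a double-bonded ring carbon. The two steps from compound 1 to compounds 2 and 3 bear on this step, since each also swaps the carbon-only aromatic ring on the same double-bonded ring carbon for a six-membered aromatic ring with one hetero atom. Those steps were small, one within the scatter and one modest beyond it, and both pointed to a higher number.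

A similar small rise is therefore expected for compound 4, with a 2.3-fold higher number from compound 1 to compound 4 (0.36 log units; beyond the scatter). Compound 4 is estimated at 0.9 nM, with a range from 0.35 nM to 2.5 nM.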

Compound 4, half-maximal inhibitory concentration: 0.15 nM
Beside the measured number, compound 4's estimate is 6.0-fold (0.78 log units) above it; the whole stated range lies above it.
By their numbers in this assay, from the lowest: compound 4; then compounds 1 and 2 (each within the scatter of the next); then compound 3.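

In this assay, among the compounds shown here, a six-membered aromatic ring with 1 hetero atom on this double-bonded ring carbon does not have to raise the number, as it did in the earlier steps: here the swap gives a 2.6-fold lower number from compound 1 to compound 4 (0.41 log units; beyond the scatter), even though the entering group has 0 hydrogen-bond donors and the leaving 4-(hydroxymethyl)phenyl has 1. The outcome at this position therefore depends on which such ring enters, and rings of the same broad kind are clearly separated, with a 3.4-fold lower number from compound 2 to compound 4 (0.53 log units; beyond the scatter) and a 7.3-fold lower number from compound 3 to compound 4 (0.87 log units; beyond the scatter). No data shown here explain why this group gives the lowest number of the four.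

The compounds leave open whether the oxygen on the ring nitrogen of compound 4 matters, or whether the plain ring without it, pyridin-3-yl, would give a similar number. They also leave open how an amine or a carboxylic acid on the aromatic ring at this position would compare with the 4-(hydroxymethyl)phenyl group of compound 1 and with the group in compound 4.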